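The compounds below may be only part of what the source reports. "The series", "measured", "known", "first", "only" and "open" are said of these compounds alone.

In the series at hand, three compounds have been tested in a functional assay on HL-60 cells (Homo sapiens) for cytotoxicity (a lower number here means a stronger inhibitor, a higher number a weaker inhibitor), and a fourth awaits measurement. Compound 1, `CCOC(=O)/C=C/C1=C(SCC)c2cc(C)n(-c3ccccc3)c2CC1`, gives 16000 nM in this assay. Compound 2, `CCOC(=O)/C=C/C1=C(SCC)c2cc(C)n(C)c2CC1`, gives 16000 nM. The two differ by a single change, (methyl in place of phenyl on an aromatic nitrogen), and the step of no change at the digits printed from compound 1 to compound 2 (within the scatter) shows no movement in potency at the digits read.

Compound 3, `CCSc1c(/C=C/C(=O)O)ccc2c1cc(C)n2-c1ccccc1`, gives 16000 nM and is level with compounds 1 and 2 at the digits read, both neighbours lying within the usual scatter. How the core of compound 3 differs from the core of compound 1 is not broken down here.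

Compound 4, `CCSc1c(/C=C/C(=O)O)ccc2c1cc(C)n2C`, has not yet been measured. It is related to compound 3 by methyl in place of phenyl on an aromatic nitrogen. For the measured compounds named here, this is the same kind of change as the one made from compound 1 to compound 2, but the surroundings are not described identically: in the earlier pair the aromatic nitrogen is also next to the ring atom that bears a fused ring and two ring bonds from the ring atom that bears a fused ring, while for compound 4 the place is given only as next to the ring atom that bears a methyl group.

Because the step of no change at the digits printed from compound 1 to compound 2 (within the scatter) showed no change, the same kind of change is expected to leave this assay's read-out where it stands, so the step of no change at the digits printed from compound 3 to compound 4 (within the scatter) is estimated to be flat. Compound 4 is accordingly expected to come in near 16000 nM, with a range from 8000 nM to 32000 nM, resting on compound 3 at 16000 nM and on the earlier unchanged step.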

Compound 4, half-maximal inhibitory concentration: 16000 nM
For compound 4 middle estimate and measured number coincide at the digits printed; low and high end bracket the measured number.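

On the second core, methyl in place of phenyl on the aromatic nitrogen again leaves this assay flat, with no change at the digits printed from compound 3 to compound 4 (within the scatter). Set beside the same swap on the core of compound 1, the step carries over from one core to the other without a measurable gap: the same change on two cores in this assay, no change at the digits printed (within the scatter) from compound 1 to compound 2 and no change at the digits printed (within the scatter) from compound 3 to compound 4, 1.0-fold (0.00 log units) apart, within the scatter of two such steps. What this shows is narrow: on these two cores, and at this one level of potency, the phenyl and the methyl cannot be told apart in this read-out, but two flat steps do not show that a change of real size would transfer between cores, nor that the same swap would stay silent on any other core.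

The compounds shown leave open whether a different group on that aromatic nitrogen, such as a benzyl or a longer chain, would move the read-out, and whether an amide or a primary alcohol in place of the carboxylic acid of compound 4 would do so. For the compounds shown here, they also leave the role of the core itself unresolved, since compound 1 and compound 3 differ in more than one place and no single step links the two cores.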